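Methylating a Phenol in a Bis-Styryl Dienone Series

The compounds below may be only part of what the source reports. "The series", "measured", "known", "first", "only" and "open" are said of these compounds alone.

Measured compounds:
compound 1 `COc1cccc(/C=C/C(=O)C(=Cc2cc(OC)c(OC)c(OC)c2)C(=O)/C=C/c2cccc(OC)c2OC)c1OC` — 220 nM
compound 2 `COc1cc(C=C(C(=O)/C=C/c2cccc(OC)c2OC)C(=O)/C=C/c2cccc(OC)c2OC)cc(OC)c1O` — 210 nM
compound 3 `COc1ccc(OC)c(/C=C/C(=O)C(=Cc2ccc(O)c(OC)c2)C(=O)/C=C/c2cc(OC)ccc2OC)c1` — 340 nM

Three compounds were tested in a functional assay on HepG2 cells (Homo sapiens) for antiproliferative activity, read by sulforhodamine B assay, with a stated time of 48 h; a higher number here means a weaker inhibitor, a lower number a stronger inhibitor. Compound 2 gives 210 nM, and compound 1, which carries the change (methyl in place of hydrogen on an oxygen on an aromatic ring), gives 220 nM. The step between them, a 1.0-fold higher number from compound 2 to compound 1 (0.02 log units; within the scatter), is small.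

Compound 3 gives 340 nM in this assay. It shares with compound 2 the hydroxy group on its central ring but differs in the two outer rings; the difference between the two cores is not broken down here, and the values of compound 3 and compound 2 lie close to one another.

Compound 4 `COc1ccc(OC)c(/C=C/C(=O)C(=Cc2ccc(OC)c(OC)c2)C(=O)/C=C/c2cc(OC)ccc2OC)c1` has not yet been measured in this assay. It stands to compound 3 as compound 1 stands to compound 2: the change is methyl in place of hydrogen on an oxygen on an aromatic ring. The place of the change is described in the same words for both pairs, an oxygen on an aromatic ring whose other neighbours are aromatic carbon, so this is the same change seen a second time, though the ring that carries it reads 4-hydroxy-3-methoxyphenyl to 3,4-dimethoxyphenyl here and 4-hydroxy-3,5-dimethoxyphenyl to 3,4,5-trimethoxyphenyl in the first pair.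

Because the earlier instance of this change gave a 1.0-fold higher number from compound 2 to compound 1 (0.02 log units; within the scatter), the step from compound 3 is expected to be similar, no change at the digits printed from compound 3 to compound 4 (within the scatter), with the caveat that it is seen only once and on a different core.

Compound 4 is therefore estimated to give about 340 nM in this assay, expected to fall between 170 nM and 700 nM.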

Compound 4, half-maximal inhibitory concentration: 260 nM
Beside the measured number, compound 4's estimate is 1.3-fold (0.12 log units) above it; low and high end bracket the measured number.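

In this assay, among these compounds, replacing 4-hydroxy-3-methoxyphenyl with 3,4-dimethoxyphenyl gives a 1.3-fold lower number from compound 3 to compound 4 (0.12 log units; within the scatter) and so, like the first instance of this change, stays within the scatter. Set side by side, the two instances do not differ: the same change on two cores in this assay, a 1.0-fold higher number (0.02 log units; within the scatter) from compound 2 to compound 1 and a 1.3-fold lower number (0.12 log units; within the scatter) from compound 3 to compound 4, 1.4-fold (0.14 log units) apart, within the scatter of two such steps. Within this small set, hydroxy and methoxy at this place could therefore be exchanged on either core with no step beyond the scatter, but two pairs do not establish that the result would hold on other cores in the series, and they do not explain why the readings stay so close.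

The compounds shown leave open whether other groups on the same oxygen or in its place, such as an ethyl group, an amine or a carboxylic acid, would also leave the reading within the scatter. They also leave open whether the exchange of hydroxy for methoxy would give a similar result if made on an oxygen on a different aromatic ring of these molecules.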